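The source may report more compounds than this note shows. Statements on the series, on what has been measured and on what is new or still open speak of the compounds shown alone.

Two measured compounds share one core. Compound 1 `O=C(NCc1cn(Cc2ccc(F)cc2)nn1)c1cn(-c2ccccc2)nc1-c1ccccc1` gives 9600 nM in a functional assay on MIA PaCa-2 cells (Homo sapiens) for antiproliferative activity, read by sulforhodamine B assay, with a stated time of 48 h; a higher number here means a weaker inhibitor of growth, a lower number a stronger inhibitor of growth. Compound 2 `O=C(NCc1cn(Cc2ccc(F)cc2)nn1)c1cn(-c2ccccc2)nc1-c1ccc(F)cc1` gives 14300 nM in this assay. The single measured step, a 1.5-fold higher number from compound 1 to compound 2 (0.17 log units; within the scatter), concerns a fluoro in place of hydrogen on an aromatic carbon of the aryl group attached to the core and lies within the scatter, so compound 2 and compound 1 cannot be separated on the numbers shown; compound 2 is simply one of the two numbers, with compound 1 as its only neighbour.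

Compound 3 `COc1cc(Cn2cc(CNC(=O)c3cn(-c4ccccc4)nc3-c3ccc(F)cc3)nn2)cc(OC)c1` is not yet measured. It differs from compound 2 in 3,5-dimethoxyphenyl in place of 4-fluorophenyl on a saturated chain carbon bound to an aromatic nitrogen, a change on the saturated chain carbon bound to an aromatic nitrogen, that is, at the benzyl substituent of the triazole rather than at the aryl group varied between compound 1 and compound 2. Within the data shown here, no measured step touches this position, and the one step available, a 1.5-fold higher number from compound 1 to compound 2 (0.17 log units; within the scatter), was within the scatter. Nothing in the data supports a shift beyond the scatter in this assay; compound 3 is therefore expected near compound 2, as a 1.0-fold lower number from compound 2 to compound 3 (0.01 log units; within the scatter), with a wide margin for the untested position. The estimate for compound 3 is 14000 nM, between 5000 nM and 40000 nM.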

Compound 3, concentration for 50% growth inhibition: 190 nM
Estimate against measurement, compound 3: 74-fold (1.87 log units) above; measured number outside the range, below it.
By their numbers in this assay, from the lowest: compound 3; then compounds 1 and 2 (each within the scatter of the next).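

In this assay, replacing 4-fluorobenzyl with 3,5-dimethoxybenzyl gives a 75-fold lower number from compound 2 to compound 3 (1.88 log units; beyond the scatter), which marks the saturated chain carbon bound to an aromatic nitrogen as a place where the series can respond strongly to a single change. Among these compounds, the only earlier step, a 1.5-fold higher number from compound 1 to compound 2 (0.17 log units; within the scatter), concerned a different place, so the lack of separation between compound 1 and compound 2 says nothing about this position. The change exchanges 4-fluorophenyl for 3,5-dimethoxyphenyl as a whole, and no available measurement bears on why the number falls at this place.

The compounds shown leave open whether both methoxy groups are needed, and whether a single methoxy group, an unsubstituted benzyl group or a longer chain carrying the 3,5-dimethoxyphenyl group would give a similar number. They also leave open whether 3,5-dimethoxybenzyl gives a step of similar size on the core of compound 1, where the aryl group carries hydrogen in place of the fluoro of compound 3.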